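The source may hold more compounds than are shown below. What is called first, only, known or untested is meant among the compounds shown, and "the series" means these compounds.

Working notes on the series. Three measured compounds share one core and differ in the group on an aromatic nitrogen. Compound 1 `Cc1cc(=O)n(-c2ccccc2C(F)(F)F)nc1C(=O)Nc1ccc(Oc2ncnc3ccsc23)c(F)c1` carries 2-(trifluoromethyl)phenyl there; in a functional assay on MCF7 cells (Homo sapiens) for cytotoxicity, read by MTT assay, with a stated time of 72 h (on this read-out higher numbers stand for weaker inhibition and lower numbers for stronger inhibition), compound 1 gives 6020 nM. Compound 2 `Cc1cc(=O)n(-c2ccccc2OC(F)(F)F)nc1C(=O)Nc1ccc(Oc2ncnc3ccsc23)c(F)c1` has trifluoromethoxy in place of trifluoromethyl on an aromatic carbon, and in this assay compound 2 gives 11500 nM; the step is a 1.9-fold higher number from compound 1 to compound 2 (0.28 log units; within the scatter). Compound 3 `Cc1cc(=O)n(-c2ccc(F)cc2)nc1C(=O)Nc1ccc(Oc2ncnc3ccsc23)c(F)c1` carries 4-fluorophenyl on the aromatic nitrogen, and in this assay compound 3 gives 740 nM, the lowest of the three numbers. The two steps leading to it are an 8.1-fold lower number from compound 1 to compound 3 (0.91 log units; beyond the scatter) and a 16-fold lower number from compound 2 to compound 3 (1.19 log units; beyond the scatter).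

Compound 4 `Cc1cc(=O)n(-c2ccc(F)cc2)nc1C(=O)Nc1ccc(Oc2ncnc3sccc23)c(F)c1` keeps the 4-fluorophenyl and alters the other end of the molecule: a group of 9 heavy atoms (6 carbon, 2 nitrogen, 1 sulfur; one five-membered aromatic ring with 1 hetero atom, one six-membered aromatic ring with 2 hetero atoms) in place of a group of 9 heavy atoms (6 carbon, 2 nitrogen, 1 sulfur; one five-membered aromatic ring with 1 hetero atom, one six-membered aromatic ring with 2 hetero atoms), on an oxygen on an aromatic ring. The two structures contain the same atoms, joined differently. Among the measured compounds shown here, none of the three measured steps touches this part of the molecule; all of them concern the group on the aromatic nitrogen, so no measured step bears on the present change and no direction can be read from the data. The expected step of a 1.4-fold higher number from compound 3 to compound 4 (0.13 log units; within the scatter) in this assay is accordingly small, possibly within the scatter, with the uncertainty set wide for lack of any comparable step. Compound 4 is estimated at 1000 nM, within a range from 300 nM to 3500 nM.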

Compound 4, half-maximal inhibitory concentration: 12300 nM
For compound 4 the middle estimate is 12-fold (1.09 log units) below the measured one, outside the stated range (above it).
By their numbers in this assay, from the lowest: compound 3; then compounds 1, 2 and 4 (each within the scatter of the next, the first and the last beyond it).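

Until now every measured step concerned the group on the aromatic nitrogen, and compound 4 shows that the group on an oxygen on an aromatic ring also governs the read-out in this assay: with the 4-fluorophenyl held constant, the change gives a 17-fold higher number from compound 3 to compound 4 (1.22 log units; beyond the scatter). The two groups hold the same atoms and the same counted hydrogen-bond donors and acceptors, so in this pair the step goes with how those atoms are joined, not with any difference in composition or in those counts, and the arrangement in compound 3 is the one that gives the lower number. No measurement at hand bears on the reason for this step.

The compounds shown leave open whether the steps seen among compounds 1, 2 and 3 for the group on the aromatic nitrogen would keep their direction and size with the arrangement in compound 4. Among the compounds shown here, they also leave open how the read-out would respond to an amine or a carboxylic acid carried on the group at the oxygen, since the only change at this place so far rearranges atoms without adding any.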